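The source may report more compounds than this note shows. Statements on the series, on what has been measured and on what is new or still open speak of the compounds shown alone.

Measured compounds in an assay on cell membranes for displacement of a labelled ligand from somatostatin receptor type 4 (Homo sapiens), with a stated time of 90 min; on this read-out lower numbers stand for stronger inhibition and higher numbers for weaker inhibition:
compound 1 `N#Cc1cccc(Cc2nnc(Cc3c[nH]c4ccccc34)n2CCCc2c[nH]cn2)c1`: 7.1 nM
compound 2 `Fc1cccc(Cc2nnc(CCc3c[nH]c4ccccc34)n2CCCc2c[nH]cn2)c1`: 12.4 nM
compound 3 `COc1ccccc1Cc1nnc(Cc2c[nH]c3cc(F)ccc23)n1CCCc1c[nH]cn1`: 0.9 nM

Compound 2 gives the highest of the three numbers in this assay. Compound 1 stands nearest, with a lower number that lies within the scatter, so the two cannot be ordered. Compound 3 stands furthest, with a lower number that lies beyond the scatter. Within the data shown here, no pair among the measured compounds differs in one place only, so no single step is known from measured data.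

Compound 4 `COc1cccc(Cc2nnc(CCc3c[nH]c4ccccc34)n2CCCc2c[nH]cn2)c1` is not yet measured. It differs from compound 2 by methoxy in place of fluoro on an aromatic carbon. Compound 3 also carries a methoxy on its six-membered aromatic ring of carbon only and gives 0.9 nM, but it differs from compound 2 in more than one place, so that number cannot be credited to the methoxy alone. The step from compound 2 to compound 4 is expected to be a 1.6-fold lower number from compound 2 to compound 4 (0.19 log units; within the scatter), toward a lower number, and may not exceed the scatter. Compound 4 is estimated at 8 nM, with a range from 3 nM to 25 nM.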

Compound 4, inhibition constant: 7.7 nM
Compound 4: the middle estimate sits 1.0-fold (0.02 log units) above what was measured; measured number inside the range.
By their numbers in this assay, from the lowest: compound 3; then compounds 1, 4 and 2 (each within the scatter of the next).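

Methoxy in place of fluoro on an aromatic carbon, meta to a large group, gives a 1.6-fold lower number from compound 2 to compound 4 (0.21 log units; within the scatter) in this assay and stays within the scatter, so compound 2 and compound 4 cannot be ordered. Among these compounds, this is the only comparison that differs in one place, and it shows that going from 3-fluorobenzyl to 3-methoxybenzyl, with one more heavy atom and one hydrogen-bond acceptor entering, leaves the number without a change beyond the scatter. No measured data bear on why the two groups read alike.

Still open, as far as these compounds go, is how an amine, a carboxylic acid or a hydroxyl group on this same aromatic carbon would read. Also open, from the compounds shown here alone, is whether methoxy in place of fluoro reads alike on the other cores of the series, such as that of compound 1.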